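Trimming the Sulfonyl Group of a Chemokine Receptor Binder

The source may hold more compounds than are shown below. What is called first, only, known or untested is meant among the compounds shown, and "the series" means these compounds.

Among the compounds with values here, compound 2 `CC[C@H]1CN(c2nc(N)c(C(=O)NCCNS(=O)(=O)C(F)(F)F)nc2Cl)CCN1C1CCN(Cc2ccc(Cl)cc2)CC1` stands lowest of the two numbers so far: in an in vitro assay on BaF3 cells for displacement of a labelled ligand from C-X-C chemokine receptor type 3 (Homo sapiens) (on this read-out higher numbers stand for weaker inhibition and lower numbers for stronger inhibition), compound 2 gives 0.9 nM, while compound 1 `CC[C@H]1CN(c2nc(N)c(C(=O)NCC(C)(C)O)nc2Cl)CCN1C1CCN(Cc2ccc(Cl)cc2)CC1` gives 8.4 nM. Within the data shown here, the only measured step, a 9.3-fold lower number from compound 1 to compound 2 (0.97 log units; beyond the scatter), changed a different part of the side chain. Compound 3 `CC[C@H]1CN(c2nc(N)c(C(=O)NCCNS(C)(=O)=O)nc2Cl)CCN1C1CCN(Cc2ccc(Cl)cc2)CC1` differs from compound 2 by methyl in place of trifluoromethyl on a sulfonyl sulfur. Among the measured compounds shown here, no measured step touches the substituent on the sulfonyl sulfur, so that one step is only a loose guide. The step of a 2.8-fold higher number from compound 2 to compound 3 (0.44 log units; beyond the scatter) is expected to be a modest rise, putting compound 3 at an estimated 2.5 nM with a range of 0.9 nM to 8 nM.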

Compound 3, half-maximal inhibitory concentration: 4.4 nM
Compound 3: middle estimate off by 1.8-fold (0.25 log units), on the low side; the range from low to high includes it.
By their numbers in this assay, from the lowest: compound 2; then compounds 3 and 1 (each within the scatter of the next).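

The group on the sulfonyl sulfur matters in this assay, since methyl in place of trifluoromethyl gives (a 4.9-fold higher number from compound 2 to compound 3 (0.69 log units; beyond the scatter)). With methyl on the sulfur, the sulfonamide chain no longer stands apart from the 1-hydroxy-1-methylethyl chain (a 1.9-fold lower number from compound 1 to compound 3 (0.28 log units; within the scatter)), so among these compounds the edge of compound 2 goes with the trifluoromethyl and not with the sulfonamide alone. Nothing given here accounts for this difference. Where an ethyl or a phenyl on the sulfonyl sulfur would fall relative to compound 2 and compound 3 stays open.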